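The source may report more compounds than this note shows. Statements on the series, on what has been measured and on what is new or still open speak of the compounds shown alone.

In an assay on HEK293 cells for displacement of a labelled ligand from Sigma non-opioid intracellular receptor 1 (Homo sapiens), read by scintillation counting, with a stated time of 120 min (on this read-out higher numbers stand for weaker inhibition and lower numbers for stronger inhibition), the three measured compounds give these numbers:
compound 1 `Clc1ccccc1-c1ncnc2c1cnn2CCN1CCCCC1`: 76 nM
compound 2 `Clc1ccc(-c2ncnc3c2cnn3CCN2CCCCC2)cc1`: 43 nM
compound 3 `Cc1cc(F)ccc1-c1ncnc2c1cnn2CCN1CCCCC1`: 48 nM

Compound 3 holds the second highest of the three numbers, but its gaps to compound 2 and to compound 1 both lie within the scatter, so no order among the three can be read. All three measured steps change the group on the same aromatic carbon of the shared core: a 1.8-fold lower number from compound 1 to compound 2 (0.25 log units; within the scatter), a 1.6-fold lower number from compound 1 to compound 3 (0.20 log units; within the scatter) and a 1.1-fold higher number from compound 2 to compound 3 (0.05 log units; within the scatter), none beyond the scatter. Compound 4 `Cc1ccncc1-c1ncnc2c1cnn2CCN1CCCCC1` alters that same group: 4-methylpyridin-3-yl in place of 4-fluoro-2-methylphenyl on an aromatic carbon. Going by the values given here, no measured step brings a ring nitrogen into this group, so the measured steps bear on it only indirectly; because a 1.1-fold higher number from compound 2 to compound 3 (0.05 log units; within the scatter) and a 1.6-fold lower number from compound 1 to compound 3 (0.20 log units; within the scatter) stay within the scatter, swaps within this group have so far moved this assay little. The ring nitrogen is a larger departure, and a modest step toward a higher number is expected, a 2.1-fold higher number from compound 3 to compound 4 (0.32 log units; beyond the scatter), though a step within the scatter remains plausible. Compound 4 is therefore estimated at 100 nM, in a range from 35 nM to 300 nM.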

Compound 4, inhibition constant: 707 nM
Compound 4: middle estimate off by 7.1-fold (0.85 log units), on the low side; the whole stated range lies below it.
By their numbers in this assay, from the lowest: compounds 2, 3 and 1 (each within the scatter of the next); then compound 4.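

Earlier swaps on this aromatic carbon, all among phenyl rings of carbon only, stayed within the scatter in this assay and gave no sign that the position could respond strongly. Going by these compounds alone, the 4-methylpyridin-3-yl group, whose ring nitrogen none of those phenyl groups carries, brings the first changes here beyond the scatter: a 15-fold higher number from compound 3 to compound 4 (1.17 log units; beyond the scatter) and a 16-fold higher number from compound 2 to compound 4 (1.22 log units; beyond the scatter) and also a 9.3-fold higher number from compound 1 to compound 4 (0.97 log units; beyond the scatter). All three steps run the same way, yet nothing measured here explains the rise.

The compounds shown leave open whether the ring nitrogen alone accounts for this, since compound 4 also differs from each phenyl compound in its other ring substituents. On these data alone, a plain 4-methylphenyl group on this carbon would separate those two differences, and the effect of a methoxy group or an amine on the ring also remains open.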